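Swapping ethoxy for morpholin-4-yl on compound 2

The source may report more compounds than this note shows. Statements on the series, on what has been measured and on what is new or still open speak of the compounds shown alone.

Compound 1 `NNC(=O)CCc1ccncc1-c1ccc2ccccc2c1` gives > 10000 nM
Compound 2 `CCOC(=O)/C=C/c1ccncc1-c1ccc2ccccc2c1` gives 8090 nM
Compound 3 `CNC(=O)CCc1ccncc1-c1ccc2ccccc2c1` gives 8980 nM

All three compounds were tested in a functional assay on MDA-MB-231 cells (Homo sapiens) for inhibition, read by sulforhodamine B assay, with a stated time of 72 h; on this read-out lower numbers stand for stronger inhibition of growth and higher numbers for weaker inhibition of growth. Compound 1 is reported only as a limit, > 10000 nM, and not as a number. Among the compounds with values here, compound 2 gives 8090 nM, a value within the scatter of the one other true number, that of compound 3. Both steps from compound 1 are floors within the scatter: an at least 1.2-fold lower number from compound 1 to compound 2 (0.09 log units; that floor lies within the scatter) and an at least 1.1-fold lower number from compound 1 to compound 3 (0.04 log units; that floor lies within the scatter).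

Compound 4 `O=C(/C=C/c1ccncc1-c1ccc2ccccc2c1)N1CCOCC1` has not yet been measured. It differs from compound 2 in one place, with morpholin-4-yl in place of ethoxy on a carbonyl carbon. Within the data shown here, no measured step isolates this change. The closest is from compound 2, where 2-(methylcarbamoyl)ethyl replaces 2-(ethoxycarbonyl)ethenyl: a 1.1-fold higher number from compound 2 to compound 3 (0.05 log units; within the scatter). On that single comparison, no step beyond the scatter is expected, and the estimated step is a 1.1-fold higher number from compound 2 to compound 4 (0.05 log units; within the scatter). Compound 4 is estimated at 9000 nM, with an expected range from 4500 nM to 18000 nM.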

Compound 4, concentration for 50% growth inhibition: 8980 nM
The estimate for compound 4 lay 1.0-fold (0.00 log units) above the measured number; the range from low to high includes it.
By their numbers in this assay, from the lowest: compounds 2, 3 and 4 (each within the scatter of the next). At a limit, above all of these: compound 1.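

At the carbonyl carbon of compound 2, ethoxy can give way to morpholin-4-yl, with its six-membered non-aromatic ring, without a step beyond the scatter in this assay: a 1.1-fold higher number from compound 2 to compound 4 (0.05 log units; within the scatter). Within the data shown here, this step is confined to that one group and keeps the double-bonded chain carbon in place, whereas the earlier steps replaced the whole chain or changed the group on an amide-type nitrogen. Compound 4 adds a true number to the series, and the one limit remains that of compound 1: the limit of > 10000 nM in this assay, at which 1 of the 4 values shown sits.

Going by these compounds, whether a carboxylic acid or a piperazine at this carbonyl carbon would give a step beyond the scatter stays open. None of the steps shown lies beyond the scatter, and they do not tell which part of these compounds governs the growth inhibition.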